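A few compounds are considered here, and "the series" means these few. Any claim that something is new, unique, unknown or untested is made for them only; others in the source may bear on it.

Within the data shown here, compound 3 `CCCNc1nc(NCc2ccc(C(=O)N3CCC(C(=O)NCc4ccc(F)cc4)CC3)cc2)c2ccccc2n1` is one of three compounds measured in a functional assay on HCT-116 cells (Homo sapiens) for inhibition, read by luminescence and resazurin assay, with a stated time of 3 days (on this read-out higher numbers stand for weaker inhibition and lower numbers for stronger inhibition), where compound 3 gives 5500 nM. Compound 1 `CCCNc1nc(NCc2ccc(C(=O)N3CCC(C(=O)NCc4ccc(F)cc4)CC3)cc2)c2cc(C)ccc2n1` gives 4600 nM in this assay, and compound 2 `CN(C)CCCNc1nc(NCc2ccc(NC(=O)c3ccc(F)cc3)cc2)c2ccccc2n1` gives 10000 nM. Compound 3 thus stands second highest of the three numbers, nearest to compound 1 and furthest from compound 2, though both gaps lie within the scatter. Among the measured compounds shown here, the only step between two measured compounds that differ in one place is a 1.2-fold higher number from compound 1 to compound 3 (0.08 log units; within the scatter), a change on the shared core that left the number essentially unchanged.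

Compound 4 `CN(C)c1nc(NCc2ccc(C(=O)N3CCC(C(=O)NCc4ccc(F)cc4)CC3)cc2)c2ccccc2n1` differs from compound 3 by dimethylamino in place of propylamino on an aromatic carbon. For the measured compounds named here, no measured pair shows this particular exchange, so the step cannot be anchored directly. Going by the values given here, the one measured step, which also sits on the shared core, was within the scatter, and compound 2, which carries a different substituent on that carbon along with other changes, gives a number not far from compound 3. Compound 4 is therefore expected to show no step beyond the scatter, a 1.1-fold higher number from compound 3 to compound 4 (0.04 log units; within the scatter), and its value in this assay is estimated at 6000 nM, within a range from 2000 nM to 20000 nM.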

Compound 4, half-maximal inhibitory concentration: 5700 nM
Beside the measured number, compound 4's estimate is 1.1-fold (0.02 log units) above it, and the stated range covers the measured number.
By their numbers in this assay, from the lowest: compounds 1, 3, 4 and 2 (each within the scatter of the next, the first and the last beyond it).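

Replacing propylamino with dimethylamino on the aromatic carbon between two ring nitrogen atoms gives a 1.0-fold higher number from compound 3 to compound 4 (0.02 log units; within the scatter) in this assay. Among these compounds, this is the first measured step at this position, as the earlier step lay at another place on the shared core, and it shows that a group with 0 hydrogen-bond donors can stand here in place of one with 1 while the number stays within the scatter. Nothing shown here offers an explanation for this flat result.

The compounds shown leave open whether a longer chain, a morpholine ring or a carboxylic acid at this position would move the number beyond the scatter. They also leave open whether the same exchange would give a similar step on the methyl-bearing core of compound 1.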